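The compounds below may be only part of what the source reports. "The series", "measured", "known", "first", "only" and "open" are said of these compounds alone.

Measured in a functional assay on CHO cells with adenosine receptor A1 (Homo sapiens) as the target, read by cAMP accumulation and immunoassay, with a stated time of 6 min, tested at 1 uM; a higher number here means a weaker effect of the compound at the concentration tested, a lower number a stronger effect:

Compound 1 `Nc1scc(CN2CCN(c3ccc([N+](=O)[O-])cc3)CC2)c1C(=O)c1ccc(Cl)cc1`: -8.3%
Compound 2 `Nc1scc(CN2CCN(c3cccnc3)CC2)c1C(=O)c1ccc(Cl)cc1`: -2.7%

Both numbers lie close to zero, so neither compound shows a marked effect at the concentration tested. Compound 2 and compound 1 sit within the usual scatter of each other; the step of a number 5.6 percentage points higher from compound 1 to compound 2 (within the scatter) does not separate them, and no order between the two can be read from these numbers.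

The next compound, compound 3 `Nc1scc(CN2CCN(c3cccc(F)c3)CC2)c1C(=O)c1ccc(Cl)cc1`, differs from compound 2 in one place: 3-fluorophenyl in place of pyridin-3-yl on an amine nitrogen in a ring. Within the data shown here, the only measured step at this same place is the one from 4-nitrophenyl to pyridin-3-yl on the amine nitrogen in the ring, a number 5.6 percentage points higher from compound 1 to compound 2 (within the scatter), which stayed within the scatter. Among the measured compounds shown here, with one step of that size as the only guide, the exchange of pyridin-3-yl for 3-fluorophenyl is expected to leave the read-out in this assay at about the same low level, without a step beyond the scatter in either direction. The expected step is a number 0.3 percentage points lower from compound 2 to compound 3 (within the scatter). Compound 3 is therefore estimated at -3% in this assay, with a range from -15% to 10%.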

Compound 3, a percentage reported as activity, at one concentration (the size of the read-out at that concentration, not a potency): -86%
For compound 3 the middle estimate is 83 percentage points above the measured one; measured number below the stated range.
By their numbers in this assay, from the lowest: compound 3; then compounds 1 and 2 (each within the scatter of the next).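

The exchange for 3-fluorophenyl on the amine nitrogen in the ring gives, in this assay, a number 83.3 percentage points lower from compound 2 to compound 3 (beyond the scatter), and the same exchange starting from 4-nitrophenyl gives a number 77.7 percentage points lower from compound 1 to compound 3 (beyond the scatter), so this position can carry a large change in the read-out, which the earlier pair did not reveal. Compound 3 alone shows a marked effect at the concentration tested, and the change from compound 2 swaps a ring with one hetero atom and one hydrogen-bond acceptor for a carbon-only ring bearing fluorine, though the numbers cannot assign the step to either feature. Nothing available explains the size of this step.

As far as these compounds go, it remains open whether the fluorine itself matters or whether a carbon-only ring is enough, and an unsubstituted phenyl or a chlorophenyl on the same nitrogen would address that question. These read-outs also come from a single concentration, so the potency of compound 3 and its behaviour with other groups on the core remain undefined.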